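The compounds below may be only part of what the source reports. "The series", "measured", "known", "first", "only" and "open" are said of these compounds alone.

Compound 2 has the structure `CNC(=O)c1cccc2c1CCC2c1ncc[nH]1`. In a functional assay on CHO cells for agonist activity at Alpha-1B adrenergic receptor (Homo sapiens), read by FLIPR and calcium flux (a higher number here means that more compound is needed for the effect, a lower number that less compound is needed), compound 2 gives > 10000 nM, which is a limit of the assay and not a number. Compound 2 therefore stands at the limit of > 10000 nM in this assay, at which 1 of the 2 values shown sits. Its measured neighbour, compound 1 with the structure `c1cc(-c2ccn[nH]2)c2c(c1)C(c1ncc[nH]1)CC2`, gives 600 nM in this assay. Going by the values given here, the one step between them, an at least 16-fold higher number from compound 1 to compound 2 (1.22 log units; beyond the scatter), shows that exchanging the 1H-pyrazol-5-yl group of compound 1 for a methylcarbamoyl group costs a large amount of activity.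

Compound 3, with the structure `c1cc(-c2ncco2)c2c(c1)C(c1ncc[nH]1)CC2`, has not yet been measured. It differs from compound 2 in one place: 1,3-oxazol-2-yl in place of methylcarbamoyl on an aromatic carbon. This change removes the methylcarbamoyl group that went with the loss seen in the step from compound 1 to compound 2 and puts a five-membered aromatic ring back in its place, as compound 1 also carries a five-membered aromatic ring there. Because the step of an at least 16-fold higher number from compound 1 to compound 2 (1.22 log units; beyond the scatter) was large, a large step in the opposite direction is expected here, giving a lower number. The estimate for compound 3 is an expected 2000 nM, with a range from 500 nM to 10000 nM, corresponding to an expected step of an at least 5.0-fold lower number from compound 2 to compound 3 (0.69 log units; beyond the scatter).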

Compound 3, half-maximal effective concentration: > 10000 nM
Compound 3: a limit, no number (the forecaster's own chance of this, stated with the estimate: 35%); middle value at least 5.0-fold (0.69 log units) from the limit.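

In this assay, the value of compound 3, > 10000 nM, is a limit of the assay and not a number. The step of an at least 16-fold higher number from compound 1 to compound 3 (1.22 log units; beyond the scatter) is large, and it stands alongside the step of an at least 16-fold higher number from compound 1 to compound 2 (1.22 log units; beyond the scatter), so on this aromatic carbon a five-membered aromatic ring as such is not enough to keep the activity of compound 1: the 1,3-oxazol-2-yl ring and the non-ring methylcarbamoyl group both fall far short of the 1H-pyrazol-5-yl ring. The step between compound 2 and compound 3 cannot be read, and the two compounds cannot be put in order against each other: the limit of > 10000 nM in this assay, at which 2 of the 3 values shown sit.

As far as these compounds go, how far compound 2 and compound 3 lie beyond the limit stays unknown, so any real difference between methylcarbamoyl and 1,3-oxazol-2-yl remains hidden. From the compounds shown here alone, it is also open which replacements at this place would stay close to compound 1, at 600 nM, for instance an imidazole or a triazole ring, or a small group such as an amine.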